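This account rests on a few compounds, and the source may have more. Where it says the series, first, only, none or still open, it means among the compounds named here.

In a functional assay on RS4-11 cells (Homo sapiens) for inhibition, read by CCK-8 assay, with a stated time of 48 h (on this read-out higher numbers stand for weaker inhibition and lower numbers for stronger inhibition), compound 1 `COc1ccc(Oc2ccc(C(C)C)cc2-c2ccsc2S(=O)(=O)NCCNC(=S)Nc2ccc([N+](=O)[O-])cc2)cc1OC` gives 5800 nM, and compound 2 `CC(C)c1ccc(Oc2ccc(O)c(O)c2)c(-c2ccsc2S(=O)(=O)NCCNC(=S)Nc2ccc([N+](=O)[O-])cc2)c1` gives 5100 nM. The two differ only by 3,4-dihydroxyphenyl in place of 3,4-dimethoxyphenyl on an oxygen on an aromatic ring, and that change made a 1.1-fold lower number from compound 1 to compound 2 (0.06 log units; within the scatter). Compound 3 `COc1ccc(Oc2ccccc2-c2ccsc2S(=O)(=O)N2CCN(C(=S)Nc3cc(C(F)(F)F)cc(C(F)(F)F)c3)CC2)cc1OC` has a different core, and how its core differs from that of compound 1 is not broken down here. For compound 3 this assay reports only a limit, > 50000 nM, as shown by the limit of > 50000 nM in this assay, at which 1 of the 3 values shown sits. Compound 4 `O=S(=O)(c1sccc1-c1ccccc1Oc1ccc(O)c(O)c1)N1CCN(C(=S)Nc2cc(C(F)(F)F)cc(C(F)(F)F)c2)CC1` is not yet measured; it differs from compound 3 by 3,4-dihydroxyphenyl in place of 3,4-dimethoxyphenyl on an oxygen on an aromatic ring, the same change as between compound 1 and compound 2, at the same place. Because that change earlier gave a 1.1-fold lower number from compound 1 to compound 2 (0.06 log units; within the scatter), the expected step here is a step that the limit leaves unreadable from compound 3 to compound 4, and compound 4 is expected to sit at about 60000 nM, most likely again reported only as a limit.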

Compound 4, half-maximal inhibitory concentration: 7300 nM
The estimate for compound 4 lay 8.2-fold (0.91 log units) above the measured number, outside the stated range (below it).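

In this assay, putting 3,4-dihydroxyphenyl in place of 3,4-dimethoxyphenyl gave an at least 6.8-fold lower number from compound 3 to compound 4 (0.83 log units; beyond the scatter). The size of this change did not carry over from one core to the other: the same change on two cores in this assay, a 1.1-fold lower number (0.06 log units; within the scatter) from compound 1 to compound 2 and an at least 6.8-fold lower number (0.83 log units; beyond the scatter) from compound 3 to compound 4, at least 6.0-fold (0.77 log units) apart, beyond the scatter of two such steps. For compound 3 the value > 50000 nM is a limit and not a number, which leaves the true size of the step unknown, and two pairs cannot show why the cores respond differently or how a further core would respond.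

The compounds shown leave open which part of the two cores sets the size of the step. Also open, on these data alone, is how a carboxylic acid or an amine in place of the hydroxyl groups of 3,4-dihydroxyphenyl would read in this assay.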